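Benzyl on the hydroxycarbamoyl oxygen of compound 2

The compounds below may be only part of what the source reports. "The series", "measured", "known", "first", "only" and "open" are said of these compounds alone.

In a physicochemical assay (Rattus norvegicus), two compounds sharing one core have been measured so far. Compound 1 (`CCCCc1nc(Cl)c(CO)n1Cc1ccc(-c2ccccc2-c2[nH]nnc2C(=O)OC)cc1`) gives 7. Compound 2 (`CCCCc1nc(Cl)c(CO)n1Cc1ccc(-c2ccccc2C(=O)NO)cc1`) gives 10.5, the higher of the two numbers. Going by the values given here, the only measured step is a number 3.50 log units higher from compound 1 to compound 2 (beyond the scatter), a large one, in which hydroxycarbamoyl takes the place of 4-(methoxycarbonyl)-1H-1,2,3-triazol-5-yl on an aromatic carbon.

Compound 3 (`CCCCc1nc(Cl)c(CO)n1Cc1ccc(-c2ccccc2C(=O)NOCc2ccccc2)cc1`) carries benzyl in place of hydrogen on an oxygen, turning hydroxycarbamoyl into (benzyloxy)carbamoyl: benzyl in place of hydrogen on an oxygen. The measured step exchanged a whole group, whereas this change leaves the rest of the hydroxycarbamoyl group in place. Among the compounds with values here, no measured pair tests a substitution on that oxygen, so the large step gives only weak guidance and its size is not carried over. The estimate therefore starts from compound 2 at 10.5. The expected change is small and not beyond the scatter, a number 0.20 log units lower from compound 2 to compound 3 (within the scatter). For compound 3 the estimated value is 10.3, with an expected range from 9.3 to 11.2.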

Compound 3, acid dissociation constant: 10.9
The estimate for compound 3 lay 0.60 log units below the measured number; the measured number falls inside the stated range.
By their numbers in this assay, from the lowest: compound 1; then compound 2; then compound 3.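

In this assay, benzyl in place of hydrogen on the oxygen gives a number 0.40 log units higher from compound 2 to compound 3 (beyond the scatter), a modest step but one beyond the scatter, so a substitution at this oxygen does register in the read-out, and it raises the number rather than lowering it. The hydrogen on that oxygen is therefore not required for the high number seen with hydroxycarbamoyl. The exchange of the whole group reads a number 3.90 log units higher from compound 1 to compound 3 (beyond the scatter), a large step that leaves (benzyloxy)carbamoyl, like hydroxycarbamoyl, far above the 4-(methoxycarbonyl)-1H-1,2,3-triazol-5-yl group of compound 1, and nothing available accounts for the shift produced on the oxygen.

Benzyl is the only group shown on this oxygen, so the compounds leave open whether the rise belongs to benzyl itself or would also follow from a smaller group such as methyl or from a longer alkyl chain. They also leave open what a methyl group on the amide-type nitrogen would do, and whether a fluorine or a methoxy group on the benzyl ring would move the number any further.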